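From a Ring Amine to an Open Chain

The source may hold more compounds than are shown below. What is called first, only, known or untested is meant among the compounds shown, and "the series" means these compounds.

Compound 1 (`COc1ccc(/C=C\c2cc(OC)c(OC)c(OC)c2)cc1OCc1ccc(CN[C@H](C(=O)O)[C@H](C)O)cc1`) returns only a limit of the assay (> 10000 nM) in a functional assay on HepG2 cells (Homo sapiens) for antiproliferative activity, read by CCK-8 assay, with a stated time of 48 h (a higher number here means a weaker inhibitor, a lower number a stronger inhibitor), and so gives no true number. For the measured compounds named here, compound 2 (`COc1ccc(/C=C\c2cc(OC)c(OC)c(OC)c2)cc1OCc1ccc(CN2CC[C@H](O)C2)cc1`) gives 6600 nM in this assay and holds the only real number so far. Compound 3 (`COc1ccc(/C=C\c2cc(OC)c(OC)c(OC)c2)cc1OCc1ccc(CNCCN(C)C)cc1`) shares the core of compound 2 but carries (2-(dimethylamino)ethyl)amino in place of 3-hydroxypyrrolidin-1-yl on a saturated chain carbon bound to an aromatic carbon. Going by the values given here, the only measured step at this place (an at least 1.5-fold lower number from compound 1 to compound 2 (0.18 log units; that floor lies within the scatter)) has a floor within the scatter and offers no firm direction, so no change beyond the scatter is expected in this assay for the new group. An estimated 1.3-fold lower number from compound 2 to compound 3 (0.12 log units; within the scatter) is what this suggests. The estimated value for compound 3 is 5000 nM (expected range 1800 nM to 14000 nM).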

Compound 3, half-maximal inhibitory concentration: 4400 nM
Compound 3: the middle estimate sits 1.1-fold (0.06 log units) above what was measured; the range from low to high includes it.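

Swapping 3-hydroxypyrrolidin-1-yl for the open chain (2-(dimethylamino)ethyl)amino gives a 1.5-fold lower number from compound 2 to compound 3 (0.18 log units; within the scatter) in this assay, so this position tolerates losing the ring, and no gain or loss can be claimed. For the compounds shown here, the first step at this position to clear the scatter is an at least 2.2-fold lower number from compound 1 to compound 3 (0.35 log units; beyond the scatter), with 2-(dimethylamino)ethyl in place of 1-carboxy-2-hydroxypropyl on an amine nitrogen. Its true size stays unknown, as compound 1 gives only a limit of the assay, not a number: the limit of > 10000 nM in this assay, at which 1 of the 3 values shown sits.

The compounds shown leave open whether a longer chain, such as (3-(dimethylamino)propyl)amino, or a ring with two nitrogens, such as piperazin-1-yl, would give a lower number at this place. They also cannot show which part of 1-carboxy-2-hydroxypropyl is tied to the step, as the whole group leaves at once.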